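Replacing 4-Cyanophenyl with 3-Methylphenyl in Compound 1

The compounds below may be only part of what the source reports. "The series", "measured", "known", "first", "only" and "open" are said of these compounds alone.

In a functional assay on QG-56 cells (Homo sapiens) for antiproliferative activity (on this read-out lower numbers stand for stronger inhibition and higher numbers for weaker inhibition), compound 1 (`Cn1cncc1C(O)(c1ccc(C#N)cc1)c1cc2cc([N+](=O)[O-])cc(-c3ccc(C#N)cc3)c2o1`) gives 32.6 nM, the higher of two numbers, while compound 2 (`COc1cccc(-c2cc(C=O)cc3cc(C(O)(c4ccc(C#N)cc4)c4cncn4C)oc23)c1`) gives 15.2 nM, a gap beyond the scatter. Compound 3 (`Cc1cccc(-c2cc([N+](=O)[O-])cc3cc(C(O)(c4ccc(C#N)cc4)c4cncn4C)oc23)c1`) has 3-methylphenyl in place of 4-cyanophenyl on an aromatic carbon. For the measured compounds named here, no measured step isolates this change, so in this assay only a small move toward a lower number is expected, possibly none beyond the scatter. The estimated step is a 1.5-fold lower number from compound 1 to compound 3 (0.17 log units; within the scatter). For compound 3 the expected value is 22 nM, with an estimated range of 8 nM to 60 nM.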

Compound 3, half-maximal inhibitory concentration: 23.2 nM
For compound 3 the middle estimate is 1.1-fold (0.02 log units) below the measured one; the measured number falls inside the stated range.
By their numbers in this assay, from the lowest: compounds 2, 3 and 1 (each within the scatter of the next, the first and the last beyond it).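

In this assay, for the compounds shown here, the exchange of 4-cyanophenyl for 3-methylphenyl gives a 1.4-fold lower number from compound 1 to compound 3 (0.15 log units; within the scatter) and is the first single change read at this aromatic carbon, meta to a nitro group. The nitrile and its hydrogen-bond acceptor can therefore leave this position with no shift beyond the scatter. Nothing available explains this result.

Going by these compounds, it remains open how an amine or a carboxylic acid on this phenyl ring would read. Whether 3-methylphenyl and 4-cyanophenyl would also match without the nitro group is equally unsettled.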